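Sulfonylpiperazine carbamates: phenyl to butyl on the aryl ring

This account rests on a few compounds, and the source may have more. Where it says the series, first, only, none or still open, it means among the compounds named here.

Measured so far in an assay on isolated protein for inhibition of Fatty-acid amide hydrolase 1 (Homo sapiens), read by fluorescence; on this read-out higher numbers stand for weaker inhibition and lower numbers for stronger inhibition:
compound 1 `O=C(Oc1ccc([N+](=O)[O-])cc1)N1CCN(S(=O)(=O)c2ccc(-c3ccc(Cl)c(Cl)c3)cc2)CC1`: 382 nM
compound 2 `O=C(Oc1ccc([N+](=O)[O-])cc1)N1CCN(S(=O)(=O)c2ccc(-c3ccccc3)cc2)CC1`: 437 nM

For the measured compounds named here, compound 2 and compound 1 lie within the scatter of each other; the only measured step, a 1.1-fold higher number from compound 1 to compound 2 (0.06 log units; within the scatter), is small. Compound 3 `CCCCc1ccc(S(=O)(=O)N2CCN(C(=O)Oc3ccc([N+](=O)[O-])cc3)CC2)cc1` differs from compound 2 by butyl in place of phenyl on an aromatic carbon. Going by the values given here, no measured step exchanges an aromatic ring for a chain, so the one step at hand gives no direct guide; an aryl-to-alkyl change is a larger departure than the ring substitution seen so far. A moderate weakening is expected, a 2.3-fold higher number from compound 2 to compound 3 (0.36 log units; beyond the scatter), with wide uncertainty. Compound 3 is therefore estimated at 1000 nM, between 300 nM and 4000 nM.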

Compound 3, half-maximal inhibitory concentration: 179 nM
The estimate for compound 3 lay 5.6-fold (0.75 log units) above the measured number; the whole stated range lies above it.
By their numbers in this assay, from the lowest: compound 3; then compounds 1 and 2 (each within the scatter of the next).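

At this position, para to a large group, an aromatic ring is not required for inhibition: butyl in place of phenyl gives a 2.4-fold lower number from compound 2 to compound 3 (0.39 log units; beyond the scatter) and butyl in place of 3,4-dichlorophenyl gives a 2.1-fold lower number from compound 1 to compound 3 (0.33 log units; beyond the scatter) in the same direction. Among these three compounds, the open chain is the better substituent, both steps being modest. Nothing available accounts for this gain. Open, on these data alone, is how the number depends on chain length, from ethyl to a longer chain such as octyl, and whether branching, as in tert-butyl, preserves the gain.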